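Fluoro for Methyl on a Low-Toxicity Sulfonamide

The source may hold more compounds than are shown below. What is called first, only, known or untested is meant among the compounds shown, and "the series" means these compounds.

Compound 2 `CCN(c1ccc(Cl)cc1C)S(=O)(=O)c1cc(Cl)ccc1Cl` is one of three close relatives tested in an ADME assay on A549 cells (Homo sapiens) for cytotoxicity, read by MTT assay; on this read-out higher numbers stand for lower toxicity in this test and lower numbers for higher toxicity in this test. Compound 2 reaches only the limit > 5000 nM, so its reading is a boundary rather than a number. Compound 1 `CCN(c1ccccc1C)S(=O)(=O)c1cc(Cl)ccc1Cl` sits at the limit > 25000 nM. Compound 3 `Cc1cc(Cl)ccc1N(CCO)S(=O)(=O)c1cc(Cl)ccc1Cl` also sits at the limit > 5000 nM. Both neighbouring steps, a step that the two limits leave unreadable from compound 1 to compound 2 and a step that the two limits leave unreadable from compound 2 to compound 3, are unreadable, and the evidence the limit of > 25000 nM in this assay, at which 1 of the 3 values shown sits, and the limit of > 5000 nM in this assay, at which 2 of the 3 values shown sit, offers no measured size to lean on. Compound 4 `CCN(c1ccc(Cl)cc1F)S(=O)(=O)c1cc(Cl)ccc1Cl` differs from compound 2 by fluoro in place of methyl on an aromatic carbon. With no readable step, no change beyond the scatter is expected, and the estimated step that the limit leaves unreadable from compound 2 to compound 4 is near nothing. Compound 4 is expected to give about 20000 nM in this assay, between 5000 nM and 80000 nM, most likely again reported only as a limit.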

Compound 4, half-maximal cytotoxic concentration: > 5000 nM
Compound 4 gave a limit, no number; the forecaster's own chance of this, stated with the estimate: 85%; the middle value is on the limit's open side.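

Compound 2 and compound 4 both give only limits in this assay, so no step can be read for fluoro in place of methyl. Going by these compounds, whether that swap changes the toxicity reading at all stays open.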